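Pyridin-3-yl in place of 3-methylphenyl on the amine carbon

The source may hold more compounds than are shown below. What is called first, only, known or untested is meant among the compounds shown, and "the series" means these compounds.

Measured so far:
compound 1 `CC(C)c1ccccc1-c1ncc(N(C)C)c(NCc2ccc(-c3cccnc3)cc2)n1`, 190 nM
compound 2 `Cc1cccc(CNc2nc(-c3ccccc3C(C)C)ncc2C)c1`, 130 nM

In an assay on a protein complex for inhibition of ubiquitin carboxyl-terminal hydrolase 1/WD repeat-containing protein 48 (Homo sapiens), read by fluorescence (on this read-out higher numbers stand for weaker inhibition and lower numbers for stronger inhibition), compound 2 gives 130 nM, the lowest of the two numbers shown; the nearest is compound 1, whose value of 190 nM lies within the usual scatter. Compound 3 `Cc1cnc(-c2ccccc2C(C)C)nc1NCc1cccnc1` differs from compound 2 by pyridin-3-yl in place of 3-methylphenyl on a saturated chain carbon bound to a nitrogen on an aromatic ring. No step between measured compounds is known, so nothing shown fixes the size of this change; compound 1 also carries a pyridin-3-yl and sits within the scatter of compound 2. A small weakening is expected, a 1.9-fold higher number from compound 2 to compound 3 (0.28 log units; within the scatter), not beyond the scatter. For compound 3 the estimate is 250 nM, between 100 nM and 700 nM.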

Compound 3, half-maximal inhibitory concentration: 1300 nM
Beside the measured number, compound 3's estimate is 5.2-fold (0.72 log units) below it, and the stated range ends below it.
By their numbers in this assay, from the lowest: compounds 2 and 1 (each within the scatter of the next); then compound 3.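

For the compounds shown here, replacing 3-methylbenzyl with (pyridin-3-yl)methyl gives a 10-fold higher number from compound 2 to compound 3 (1.00 log units; beyond the scatter) in this assay and so provides the first measured step at this position. On a saturated chain carbon bound to a nitrogen on an aromatic ring, with the rest of the molecule unchanged, pyridin-3-yl therefore does not stand in freely for 3-methylphenyl. As far as these compounds go, whether unsubstituted phenyl, pyridin-2-yl or pyridin-4-yl would keep the number of compound 2 remains open. Nothing shown bears on why the number rises.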